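The source may hold more compounds than are shown below. What is called first, only, known or untested is meant among the compounds shown, and "the series" means these compounds.

Measured so far in an ADME assay on MT4 cells (Homo sapiens) for activation, read by MTT assay; on this read-out lower numbers stand for higher toxicity in this test and higher numbers for lower toxicity in this test:
compound 1 `CCCSc1nc(Cc2c(F)cccc2Cl)cc(=O)[nH]1`, a limit: > 80000 nM
compound 2 `CCCSc1nc(C(C)c2c(F)cccc2Cl)cc(=O)[nH]1`, a limit: > 75000 nM
compound 3 `CCCSc1nc(C(C)c2c(F)cccc2Cl)c(CC)c(=O)[nH]1`, a limit: > 3000 nM

Each of these three values is a limit of this assay, not a number. The change from compound 1 to compound 2 is methyl in place of hydrogen on a saturated chain carbon bound to two aromatic carbons; its size is a step that the two limits leave unreadable from compound 1 to compound 2. The step from compound 2 to compound 3 is a step that the two limits leave unreadable from compound 2 to compound 3. The difference between the core of compound 1 and the core of compound 3 is not broken down here.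

Compound 4 `CCc1c(C(C)c2c(F)cccc2Cl)nc(SC(C)CC)[nH]c1=O` is not yet measured. It differs from compound 3 by methyl in place of hydrogen on a saturated chain carbon bound to a saturated chain carbon and a sulfur, the same kind of change as from compound 1 to compound 2, but at a different place: there the carbon is bound to two aromatic carbons, here to a saturated chain carbon and a sulfur. The measured pair gives no size for this kind of change, since the limit of > 80000 nM in this assay, at which 1 of the 3 values shown sits, and the limit of > 75000 nM in this assay, at which 1 of the 3 values shown sits, leave it unreadable. The step from compound 3 to compound 4 is expected to be a step that the limit leaves unreadable from compound 3 to compound 4, a small one, resting on the limit of > 3000 nM in this assay, at which 1 of the 3 values shown sits, for compound 3. Compound 4 is estimated at 15000 nM, expected between 3000 nM and 80000 nM.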

Compound 4, half-maximal cytotoxic concentration: > 3000 nM
Compound 4: no number, only a limit; the forecaster's own chance of this, stated with the estimate: 60%; the middle value is on the limit's open side.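

Compound 3 stands at > 3000 nM, a limit. Compound 4 stands at > 3000 nM, also a limit, so no step can be read between compound 3 and compound 4. The compounds shown leave open whether propyl to sec-butyl changes toxicity in this test at all.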